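The source may report more compounds than this note shows. Statements on the series, on what has been measured and on what is new or still open speak of the compounds shown alone.

Working notes on the series. The shared core is that of compound 1 `Cn1cc(CN2CCC[C@H](OCc3cc(Cl)cc(Cl)c3)[C@@H]2c2ccccc2)cn1`, which in an assay on isolated protein for activation of cGMP-dependent protein kinase 1 (Homo sapiens), read by ADP-Glo, with stated times of 120 min and 40 min (on this read-out higher numbers stand for an effect only at larger amounts of compound and lower numbers for an effect already at smaller amounts), gives 110000 nM. Compound 2 `Clc1cc(Cl)cc(CO[C@H]2CCCN(Cc3ccncc3)[C@H]2c2ccccc2)c1` carries pyridin-4-yl on the saturated chain carbon bound to the amine nitrogen in the ring; in this assay compound 2 gives > 200000 nM, which is a limit of the assay and not a number. Compound 3 `Clc1cc(Cl)cc(CO[C@H]2CCCN(Cc3ccc(-c4nn[nH]n4)cc3)[C@H]2c2ccccc2)c1` gives 74000 nM in this assay, the lowest of the two numbers shown; its nearest neighbour is compound 1, and the step of a 1.5-fold lower number from compound 1 to compound 3 (0.17 log units; within the scatter) lies within the scatter, so no order between these two is claimed. The step of an at least 2.7-fold lower number from compound 2 to compound 3 (0.43 log units; beyond the scatter) reads as at least modest because one side of it rests on (the limit of > 200000 nM in this assay, at which 1 of the 3 values shown sits).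

Compound 4 `O=C(O)c1ccc(CN2CCC[C@H](OCc3cc(Cl)cc(Cl)c3)[C@@H]2c2ccccc2)cc1` differs from compound 3 by carboxy in place of 2H-tetrazol-5-yl on an aromatic carbon. Among the compounds with values here, none of the measured steps touches this position; both steps leading to compound 3, a 1.5-fold lower number from compound 1 to compound 3 (0.17 log units; within the scatter) and an at least 2.7-fold lower number from compound 2 to compound 3 (0.43 log units; beyond the scatter), exchange the whole group on the saturated chain carbon, and they span from within the scatter to at least modest. For the exchange of 2H-tetrazol-5-yl for carboxy no step is shown, so the expected step of a 1.1-fold higher number from compound 3 to compound 4 (0.03 log units; within the scatter) is within the scatter. Compound 4 is estimated at 80000 nM in this assay, between 30000 nM and 200000 nM.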

Compound 4, half-maximal effective concentration: 76000 nM
Estimate against measurement, compound 4: 1.1-fold (0.02 log units) above; the range from low to high includes it.
By their numbers in this assay, from the lowest: compounds 3, 4 and 1 (each within the scatter of the next). At a limit, above all of these: compound 2.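

Within the data shown here, the exchange on the aromatic carbon para to a large group is the first step at this position, and in this assay it gives a 1.0-fold higher number from compound 3 to compound 4 (0.01 log units; within the scatter), so carboxy and 2H-tetrazol-5-yl are not told apart here, although carboxy has fewer heavy atoms and no ring. The whole 4-carboxyphenyl group also reads as 4-(2H-tetrazol-5-yl)phenyl did against the other two groups on the saturated chain carbon: a 1.4-fold lower number from compound 1 to compound 4 (0.16 log units; within the scatter) stays within the scatter, while an at least 2.6-fold lower number from compound 2 to compound 4 (0.42 log units; beyond the scatter) goes beyond it. Compound 2 stands at a limit of the assay and not at a number, and the size of that step rests on it: the limit of > 200000 nM in this assay, at which 1 of the 4 values shown sits.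

The compounds shown leave open whether anything at this aromatic carbon matters at all, as plain phenyl without a substituent does not stand among them and the two groups that do give the same reading. From the compounds shown here alone, whether a primary amide, a methyl ester or a carboxylic acid on a longer chain at the same carbon would move the number beyond the scatter also remains open.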